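A few compounds are considered here, and "the series" means these few. Any claim that something is new, unique, unknown or untested is made for them only; others in the source may bear on it.

Compound 2 `CCC(C)(C)N/C(=N\C#N)Nc1ccccc1` gives the highest number of the three compounds in a functional assay on the whole organism (blood, strain Wistar-Okamoto) with Rattus norvegicus as the target, with a stated time of 5 days (a higher number here means that more compound is needed for the effect, a lower number that less compound is needed), namely 50 mg/kg. Compound 1 `CC(C)(C)C(C)(C)/N=C(\NC#N)Nc1ccncc1` needs less, at 20 mg/kg, and compound 3 `CCOc1ccccc1N/C(=N/C#N)NC(C)(C)CC` likewise needs less, at 20 mg/kg. Compound 4 `CCC(C)(C)N/C(=N\C#N)Nc1ccc(OC)cc1` differs from compound 2 by methoxy in place of hydrogen on an aromatic carbon. For the measured compounds named here, the one measured step that bears on this change is the ethoxy addition from compound 2 to compound 3, which gave a 2.5-fold lower number from compound 2 to compound 3 (0.40 log units; beyond the scatter); no measured step with a methoxy group on this ring exists. Because of a 2.5-fold lower number from compound 2 to compound 3 (0.40 log units; beyond the scatter) a modest lowering of the minimum effective dose is expected for compound 4, though the change is not the same one, so the size is uncertain. Compound 4 is therefore estimated at 25 mg/kg in this assay, within 10 mg/kg to 60 mg/kg, an expected step of a 2.0-fold lower number from compound 2 to compound 4 (0.30 log units; within the scatter).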

Compound 4, minimum effective dose: 50 mg/kg
Estimate against measurement, compound 4: 2.0-fold (0.30 log units) below, within the range that was stated.
By their numbers in this assay, from the lowest: compounds 1 and 3 (each within the scatter of the next); then compounds 2 and 4 (each within the scatter of the next).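

In this assay, methoxy in place of hydrogen on an aromatic carbon, para to a large group, gives no change at the digits printed from compound 2 to compound 4 (within the scatter). The earlier ethoxy step, a 2.5-fold lower number from compound 2 to compound 3 (0.40 log units; beyond the scatter), therefore does not carry over to this change, and adding an oxygen-linked group to this ring does not in itself lower the minimum effective dose. No measurement shown accounts for this difference between the two steps. The compounds shown leave open whether an amine, a hydroxyl or a chlorine at this same place would also leave the number level, and whether ethoxy there would match methoxy.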